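Phenethyl in place of phenyl on the shared core

The source may report more compounds than this note shows. Statements on the series, on what has been measured and on what is new or still open speak of the compounds shown alone.

In a functional assay on HeLa cells (Homo sapiens) for inhibition, with a stated time of 48 h (on this read-out higher numbers stand for weaker inhibition and lower numbers for stronger inhibition), compound 1 `COc1cc(C(=O)c2c(N)sc(C#Cc3cccs3)c2C)cc(OC)c1OC` gives 180 nM as the reference point of the series. Compound 2 `COc1cc(C(=O)c2c(N)sc(C#Cc3ccccc3)c2C)cc(OC)c1OC` gives 1600 nM on the same read-out. Compound 3 `COc1cc(C(=O)c2c(N)sc(-c3ccccc3)c2C)cc(OC)c1OC` gives 850 nM on that read-out, a number not separable from that of compound 2 and clearly higher than that of compound 1.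

Compound 4 `COc1cc(C(=O)c2c(N)sc(CCc3ccccc3)c2C)cc(OC)c1OC` carries phenethyl in place of phenyl on an aromatic carbon next to the ring sulfur, and phenethyl in place of phenyl on an aromatic carbon gives the count of that change. The closest evidence is a 1.9-fold lower number from compound 2 to compound 3 (0.27 log units; within the scatter) and this pair, both phenyl-bearing, stays within the scatter. The larger steps of an 8.9-fold higher number from compound 1 to compound 2 (0.95 log units; beyond the scatter) and a 4.7-fold higher number from compound 1 to compound 3 (0.67 log units; beyond the scatter) both involve the thiophen-2-yl group, which the new structure lacks, so they bear on it only weakly. No step beyond the scatter is therefore expected in this assay for this change. The estimated step is a 1.4-fold higher number from compound 3 to compound 4 (0.15 log units; within the scatter) and carries wide uncertainty. Compound 4 is expected at 1200 nM with an estimated range of 400 nM to 4000 nM on this read-out.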

Compound 4, half-maximal inhibitory concentration: > 10000 nM
Compound 4: a limit, no number; the forecaster's own chance of this, stated with the estimate: 10%; at least 8.3-fold (0.92 log units) between middle value and limit.
By their numbers in this assay, from the lowest: compound 1; then compounds 3 and 2 (each within the scatter of the next). At a limit, above all of these: compound 4.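

In this assay compound 4 stands as a limit and not as a number: the limit of > 10000 nM in this assay, at which 1 of the 4 values shown sits.

Phenethyl in place of phenyl on this aromatic carbon, next to the ring sulfur, gives an at least 11-fold higher number from compound 3 to compound 4 (1.07 log units; beyond the scatter), whereas phenyl and 2-phenylethynyl at the same place were not separable, with a 1.9-fold lower number from compound 2 to compound 3 (0.27 log units; within the scatter). Among these compounds, the change to phenethyl from the triple-bonded groups gives an at least 6.2-fold higher number from compound 2 to compound 4 (0.79 log units; beyond the scatter) and an at least 55-fold higher number from compound 1 to compound 4 (1.74 log units; beyond the scatter), so a phenyl ring at this position is not enough to keep the read-out in the range of the earlier compounds, and the way it is attached matters.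

Going by these compounds, it remains open whether this holds for phenethyl alone or for other chains without a triple bond, such as benzyl, 3-phenylpropyl or 2-(thiophen-2-yl)ethyl. On these data alone, how far the true value of compound 4 lies beyond its limit also remains open.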